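Triazolyl-aryl sulfonamides on the shared core: next substituent

This account rests on a few compounds, and the source may have more. Where it says the series, first, only, none or still open, it means among the compounds named here.

Measured so far:
compound 1 `O=c1[nH]cc(S(=O)(=O)Nc2cccc(-c3cn(-c4ccccc4)nn3)c2)c(=O)[nH]1` — 17200 nM
compound 2 `Cc1cccc(-n2cc(-c3ccc(NS(=O)(=O)c4c[nH]c(=O)[nH]c4=O)cc3)nn2)c1` — 17500 nM

Two compounds carry the shared core into a functional assay on SGC-7901 cells (Homo sapiens) for antiproliferative activity, read by MTT assay, with a stated time of 24 h; on this read-out lower numbers stand for stronger inhibition and higher numbers for weaker inhibition. In this assay compound 1 gives 17200 nM and compound 2 gives 17500 nM. Compound 1 and compound 2 differ from each other in more than one place, and no single-change step between them is available; their two numbers lie within the usual scatter of each other, so on the numbers shown compound 2 stands level with compound 1 and neither can be told apart from the other.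

Compound 3 `O=c1[nH]cc(S(=O)(=O)Nc2ccc(-c3cn(-c4ccccc4Cl)nn3)cc2)c(=O)[nH]1` is the next member. It differs from compound 2 in one place: 2-chlorophenyl in place of 3-methylphenyl on an aromatic nitrogen. Going by the values given here, no measured step of this kind exists, and the two numbers available do not move between compounds of different substitution, so no step beyond the scatter is expected in this assay, in either direction. The step from compound 2 to compound 3 is therefore estimated as a 1.0-fold lower number from compound 2 to compound 3 (0.01 log units; within the scatter). For compound 3 the expected value is 17000 nM, with a range from 7000 nM to 40000 nM.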

Compound 3, half-maximal inhibitory concentration: 2680 nM
Estimate against measurement, compound 3: 6.3-fold (0.80 log units) above; measured number below the stated range.
By their numbers in this assay, from the lowest: compound 3; then compounds 1 and 2 (each within the scatter of the next).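

In this assay, going by these compounds alone, the swap on the aromatic nitrogen gives a 6.5-fold lower number from compound 2 to compound 3 (0.81 log units; beyond the scatter) and so provides the first readable step, which shows that the number can respond to the aryl group at this place. The change leaves the heavy-atom count, the six-membered aromatic ring of carbon only, the absence of hydrogen-bond donors and acceptors and the absence of net charge as they were, so these counts do not distinguish 3-methylphenyl from 2-chlorophenyl, although the step does. No measured information on hand accounts for this step.

The single step changes both the substituent and where it stands on the phenyl ring, so the compounds shown leave open whether the chlorine, its location or the loss of the methyl group goes with the lower number. On the same core, 3-chlorophenyl and 2-methylphenyl would separate these readings, while 2-fluorophenyl, 2-bromophenyl or 2-methoxyphenyl would show whether the step extends beyond chlorine.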